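Swapping isobutoxycarbonyl for 4-methoxyphenyl on the shared core

The source may report more compounds than this note shows. Statements on the series, on what has been measured and on what is new or still open speak of the compounds shown alone.

Compound 1 `O=C(Nc1ccc2nc(NC(=O)C3CCC3)sc2c1)c1c(Cl)cccc1Cl` gives 0.013 ug/mL in a functional assay on WI-38 VA13 cells (Homo sapiens) for cytotoxicity; on this read-out higher numbers stand for an effect only at larger amounts of compound and lower numbers for an effect already at smaller amounts.
Compound 2 `CCOC(=O)Nc1nc2ccc(NC(=O)c3c(Cl)cccc3Cl)cc2s1` gives 0.0026 ug/mL in this assay.
Compound 3 `CC(C)COC(=O)Nc1nc2ccc(NC(=O)c3c(Cl)cccc3Cl)cc2s1` gives 0.0035 ug/mL in this assay.

Compound 3 stands second highest of the three numbers. Its nearest neighbour is compound 2, a 1.3-fold higher number from compound 2 to compound 3 (0.13 log units; within the scatter), within the scatter; its furthest is compound 1, a 3.7-fold lower number from compound 1 to compound 3 (0.57 log units; beyond the scatter), beyond the scatter. Compound 4 `COc1ccc(Nc2nc3ccc(NC(=O)c4c(Cl)cccc4Cl)cc3s2)cc1` differs from compound 3 as follows: 4-methoxyphenyl in place of isobutoxycarbonyl on a nitrogen on an aromatic ring. Going by the values given here, no measured step exchanges an isobutoxycarbonyl for an aromatic ring on that nitrogen. The steps of a 5.0-fold lower number from compound 1 to compound 2 (0.70 log units; beyond the scatter) and a 3.7-fold lower number from compound 1 to compound 3 (0.57 log units; beyond the scatter) only show that altering what sits on the carbonyl carbon moved the number modestly, so the expected step of a 2.9-fold higher number from compound 3 to compound 4 (0.46 log units; beyond the scatter) is a guarded one. Compound 4 is estimated at 0.01 ug/mL, with a range from 0.002 ug/mL to 0.06 ug/mL.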

Compound 4, half-maximal effective concentration: 0.87 ug/mL
Beside the measured number, compound 4's estimate is 87-fold (1.94 log units) below it, outside the stated range (above it).
By their numbers in this assay, from the lowest: compounds 2 and 3 (each within the scatter of the next); then compound 1; then compound 4.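

On this nitrogen on an aromatic ring, the earlier exchanges kept a carbonyl attached and moved the number only modestly, while 4-methoxyphenyl, which has no carbonyl, gives far larger steps in this assay (a 250-fold higher number from compound 3 to compound 4 (2.40 log units; beyond the scatter)) and (a 330-fold higher number from compound 2 to compound 4 (2.52 log units; beyond the scatter)) and (a 67-fold higher number from compound 1 to compound 4 (1.83 log units; beyond the scatter)). All three compounds with a carbonyl on this nitrogen therefore act at much smaller amounts than compound 4. No measurement at hand explains this gap.

Still open, from the compounds shown here alone, is whether the lost carbonyl or the entering aromatic ring drives the change. A 4-methoxybenzoyl group on the same nitrogen, which holds both, would help separate the two.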